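The compounds below may be only part of what the source reports. "The series", "measured", "known", "first", "only" and "open" are said of these compounds alone.

Of the compounds shown here, three built on one shared core have been measured in a physicochemical assay for lipophilicity, using the shake flask method, in phosphate buffer, measured as octanol-water partition, at pH 7.4; a lower number here means a more polar compound, a higher number a more lipophilic compound. Compound 1 `COc1cc(-c2cc(C(=O)O)c3ccccc3n2)ccc1OCC(=O)Nc1ccccc1` gives 0.7. Compound 2 `COc1cc(-c2cc(C(=O)O)c3ccccc3n2)ccc1OCC(=O)Nc1ccccc1C` gives 0.8, and compound 3 `COc1cc(-c2cc(C(=O)O)c3ccccc3n2)ccc1OCC(=O)Nc1ccc(F)cc1` gives 1.1. Among these three numbers compound 2 holds the second highest place; its nearest neighbour is compound 1 and its furthest is compound 3, and both of those gaps sit within the scatter of the method. The step of a number 0.10 log units higher from compound 1 to compound 2 (within the scatter) and the step of a number 0.30 log units higher from compound 2 to compound 3 (within the scatter) therefore say little on their own, while the step of a number 0.40 log units higher from compound 1 to compound 3 (beyond the scatter) is the only one that clearly stands out.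

The next compound, compound 4 `COc1cc(-c2cc(C(=O)O)c3ccccc3n2)ccc1OCC(=O)Nc1cccc(Cl)c1`, has not yet been measured in this assay. Its difference from compound 2 is 3-chlorophenyl in place of 2-methylphenyl on an amide-type nitrogen. Within the data shown here, the steps that bear on this change are the one that adds a methyl, a number 0.10 log units higher from compound 1 to compound 2 (within the scatter), the one that adds a fluoro, a number 0.40 log units higher from compound 1 to compound 3 (beyond the scatter), and the one that swaps a methyl-bearing ring for a halogen-bearing ring, a number 0.30 log units higher from compound 2 to compound 3 (within the scatter). Taken together they point to a small rise, and the step from compound 2 to compound 4 is expected to be a number 0.40 log units higher from compound 2 to compound 4 (beyond the scatter). Compound 4 is therefore estimated at 1.2 in this assay, with a range from 0.8 to 1.6.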

Compound 4, distribution coefficient: 2.3
Beside the measured number, compound 4's estimate is 1.10 log units below it; measured number above the stated range.
By their numbers in this assay, from the lowest: compounds 1, 2 and 3 (each within the scatter of the next, the first and the last beyond it); then compound 4.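

In this assay, the ring on the amide-type nitrogen turns out to be far more responsive than the first three compounds suggested: chloro in place of hydrogen gives a number 1.60 log units higher from compound 1 to compound 4 (beyond the scatter), a much larger step than either a number 0.10 log units higher from compound 1 to compound 2 (within the scatter) with the methyl or a number 0.40 log units higher from compound 1 to compound 3 (beyond the scatter) with the fluoro. Exchanging one substituted ring for another can also matter a great deal, as 3-chlorophenyl in place of 2-methylphenyl gives a number 1.50 log units higher from compound 2 to compound 4 (beyond the scatter), and 3-chlorophenyl in place of 4-fluorophenyl gives a number 1.20 log units higher from compound 3 to compound 4 (beyond the scatter), which leaves compound 4 clearly the highest of the four. Nothing shown here explains why this one change moves the number so far.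

Compound 4 is the only compound with a chloro, so the compounds shown cannot separate the effect of the chloro itself from that of where it sits on the ring. From the compounds shown here alone, whether a bromo, a nitrile or an amine on the same ring would move the number as far also remains open.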